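The source may report more compounds than this note shows. Statements on the series, on what has been measured and on what is new or still open speak of the compounds shown alone.

Compound 3 `Oc1ccccc1/C=C/c1ccc2cccc(O)c2n1` and compound 1 `CCOc1ccccc1/C=C/c1ccc2cccc(O)c2n1` differ in a single place: ethyl in place of hydrogen on an oxygen on an aromatic ring. In a physicochemical assay for lipophilicity, read by HPLC (a lower number here means a more polar compound, a higher number a more lipophilic compound), compound 3 gives 3.95, while compound 1 gives 4.55, so this change produced a number 0.60 log units higher from compound 3 to compound 1 (beyond the scatter). Compound 2 `Oc1ccccc1/C=C/c1ccc2c(Cl)cc(Cl)c(O)c2n1` is built on a different core; how its core differs from that of compound 3 is not broken down here. In this assay compound 2 gives 5.07, the highest number among the three measured compounds.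

Compound 4 `CCOc1ccccc1/C=C/c1ccc2c(Cl)cc(Cl)c(O)c2n1` has not yet been measured. It differs from compound 2 by the same change seen between compound 3 and compound 1: ethyl in place of hydrogen on an oxygen on an aromatic ring. Because the earlier step was a number 0.60 log units higher from compound 3 to compound 1 (beyond the scatter), a step of similar size is expected now, namely a number 0.60 log units higher from compound 2 to compound 4 (beyond the scatter). On that basis compound 4 is expected to give 5.67 in this assay, most likely between 5.3 and 6.05.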

Compound 4, partition coefficient: 5.67
Beside the measured number, compound 4's estimate shows no gap at the digits printed; the measured number falls inside the stated range.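

In this assay the change from hydroxy to ethoxy gave a number 0.60 log units higher from compound 2 to compound 4 (beyond the scatter) and so matched a number 0.60 log units higher from compound 3 to compound 1 (beyond the scatter) in size, which means the step carried over unchanged between these two cores. Within the data shown here, this rests on only two pairs of compounds, so it does not show that the step would hold on any other core or in any other kind of assay. Nothing shown here explains why the two steps match.

The compounds shown carry only hydrogen or ethyl on this oxygen. As far as these compounds go, what a methyl, a longer chain such as butyl, or a chain ending in an amine would do there stays open.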